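Methoxy on the Benzyl Ring of a Sulfonamide Series

The source may report more compounds than this note shows. Statements on the series, on what has been measured and on what is new or still open speak of the compounds shown alone.

Measured compounds:
Compound 1, `O=S(=O)(NCCCNCc1cccc2ccccc12)c1cc(C(F)(F)F)cc(C(F)(F)F)c1`, gives 2700 nM in a functional assay on BXPC-3 cells (Homo sapiens) for inhibition, read by MTT assay, with a stated time of 72 h; on this read-out lower numbers stand for stronger inhibition of growth and higher numbers for weaker inhibition of growth.
Compound 2, `O=S(=O)(NCCCNCc1ccc(-c2ccccc2)cc1)c1cc(C(F)(F)F)cc(C(F)(F)F)c1`, gives 1700 nM.
Compound 3, `O=S(=O)(NCCCNCc1ccccc1)c1cc(C(F)(F)F)cc(C(F)(F)F)c1`, gives 13000 nM.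

Compound 3 stands highest of the three numbers: the step of a 4.8-fold higher number from compound 1 to compound 3 (0.68 log units; beyond the scatter) and the step of a 7.6-fold higher number from compound 2 to compound 3 (0.88 log units; beyond the scatter) both rise beyond the scatter, so compound 3 is the weakest of the measured set. Compound 4, `COc1ccc(CNCCCNS(=O)(=O)c2cc(C(F)(F)F)cc(C(F)(F)F)c2)cc1`, is not yet measured; it differs from compound 3 by methoxy in place of hydrogen on an aromatic carbon. Among the measured compounds shown here, no measured pair shows this exact change. The two measured steps, phenyl in place of naphthalen-1-yl and hydrogen in place of phenyl, both weaken inhibition, and the methoxy adds only a little at the same end, so only a modest gain is expected. Compound 4 is therefore estimated at 8000 nM, within 3000 nM to 20000 nM, an expected step of a 1.6-fold lower number from compound 3 to compound 4 (0.21 log units; within the scatter).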

Compound 4, concentration for 50% growth inhibition: 1300 nM
Estimate against measurement, compound 4: 6.2-fold (0.79 log units) above, and the stated range ends above it.
By their numbers in this assay, from the lowest: compounds 4, 2 and 1 (each within the scatter of the next, the first and the last beyond it); then compound 3.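

In this assay, the change from benzyl to 4-methoxybenzyl brings a 10-fold lower number from compound 3 to compound 4 (1.00 log units; beyond the scatter) and shows that one methoxy on this ring carbon, para to a large group, can recover the loss seen without a larger aryl group. Against the biphenyl-type compound the result is a 1.3-fold lower number from compound 2 to compound 4 (0.12 log units; within the scatter) and against the naphthalene-bearing compound it is a 2.1-fold lower number from compound 1 to compound 4 (0.32 log units; beyond the scatter) so the methoxy matches the first and goes slightly past the second. Nothing measured here bears on why this happens. The compounds shown leave open whether hydroxy, fluorine or a nitrile at this place would give a similar drop, and whether the methoxy gain survives a longer chain.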